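Swapping benzyl for hydrogen on compound 2

The source may hold more compounds than are shown below. What is called first, only, known or untested is meant among the compounds shown, and "the series" means these compounds.

Compound 1 `COC(=O)/C=C/c1cc(Br)c(OC)c(Br)c1O`: > 14000 nM, a limit
Compound 2 `COc1c(Br)cc(/C=C2\N=C(c3ccccc3)OC2=O)c(OCc2ccccc2)c1Br`: 921000 nM
Compound 3 `COc1c(Br)cc(C=O)c(OCc2cc(N(C)C)ccc2Br)c1Br`: > 19000 nM, a limit

All three values come from an ADME assay on BAEC cells (Bos taurus) for cytotoxicity, read by MTT assay, with a stated time of 2 days; on this read-out lower numbers stand for stronger inhibition and higher numbers for weaker inhibition. For the measured compounds named here, compound 2 holds the only actual number among them, while the other two values are limits. Compound 4 `COc1c(Br)cc(/C=C2\N=C(c3ccccc3)OC2=O)c(O)c1Br` differs from compound 2 in one place: hydrogen in place of benzyl on an oxygen on an aromatic ring, or benzyloxy to hydroxy. Going by the values given here, no measured pair shows this change, so any forecast is uncertain. In this assay the estimated step of a 6.1-fold lower number from compound 2 to compound 4 (0.79 log units; beyond the scatter) is expected to point toward a lower number, meaning stronger inhibition. This expectation rests only on the very high number of compound 2 at 921000 nM. For compound 4 the expected value is 150000 nM, with an estimated range of 20000 nM to 1000000 nM.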

Compound 4, half-maximal inhibitory concentration: > 22000 nM
Compound 4: a limit, no number; the forecaster's own chance of this, stated with the estimate: 35%; the middle value does not contradict the limit.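

For the compounds shown here, compound 4 gives a limit and not a number, so no step from compound 2 to compound 4 can be read. From the compounds shown here alone, whether hydrogen in place of benzyl on the aromatic oxygen shifts the read-out, and in which direction, remains open.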